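Swapping the aryl arm for a branched alkyl chain

The source may hold more compounds than are shown below. What is called first, only, known or untested is meant among the compounds shown, and "the series" means these compounds.

In an ADME assay on MDBK cells (Bos taurus) for cytotoxicity (a lower number here means that less compound is tolerated, a higher number that more compound is tolerated), compound 1 `Clc1ccc(Cn2ccc3nc(-c4ccccc4)nc-3c2)cc1` gives only a limit of the assay, > 100000 nM. Compound 2 `FC(F)(F)c1ccc(Cn2ccc3nc(-c4ccccc4)nc-3c2)cc1` carries trifluoromethyl in place of chloro on an aromatic carbon and gives 84000 nM in this assay. Within the data shown here, the single measured step, an at least 1.1-fold lower number from compound 1 to compound 2 (0.07 log units; that floor lies within the scatter), tells little, since it rests on the limit of > 100000 nM in this assay, at which 1 of the 2 values shown sits, and its floor lies within the scatter.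

Compound 3 `CCC(CC)Cn1ccc2nc(-c3ccccc3)nc-2c1` differs from compound 1 in another way: pentan-3-yl in place of 4-chlorophenyl on a saturated chain carbon bound to an aromatic nitrogen. Among the measured compounds shown here, no measured step touches a change of this kind, so the one step that exists does not bear on it directly; it shows only that the shared core with a benzylic arm is tolerated up to the limit of the assay. With no evidence that trading the ring for a pentan-3-yl chain alters what the cells tolerate, compound 3 is expected to stay near the top of the measured range in this assay, which is a step of a number no higher from compound 1 to compound 3 (the limit leaves the size open). The estimate for compound 3 is 100000 nM, with a range from 35000 nM to 300000 nM.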

Compound 3, half-maximal cytotoxic concentration: > 100000 nM
Compound 3: only a limit was reported (the forecaster's own chance of this, stated with the estimate: 50%); the middle value sits exactly at the limit.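

The step from compound 1 to compound 3 cannot be read in this assay, since each of the two compounds gives only a limit of the assay: the limit of > 100000 nM in this assay, at which 2 of the 3 values shown sit.

The compounds shown leave open whether pentan-3-yl in place of 4-chlorophenyl changes how much compound the cells tolerate, and by how much.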